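The source may report more compounds than this note shows. Statements on the series, on what has been measured and on what is new or still open speak of the compounds shown alone.

In a functional assay on A549 cells (Homo sapiens) for antiproliferative activity, read by sulforhodamine B assay, with a stated time of 48 h (a lower number here means a stronger inhibitor, a higher number a weaker inhibitor), compound 1 (`COc1cc(C(=O)/C=C\Nc2ccc(-c3nc4cc(OC)c(OC)c(OC)c4s3)cc2C)cc([N+](=O)[O-])c1OC`) gives 17400 nM and compound 2 (`COc1cc(OC)c2sc(-c3ccc(N/C=C\C(=O)c4ccc(OC)c([N+](=O)[O-])c4)c(C)c3)nc2c1`) gives 12100 nM here, so compound 2 lies within the usual scatter of compound 1 and the two numbers cannot be told apart. Compound 3 (`COc1cc(OC)c2sc(-c3ccc(N/C=C\C(=O)c4cc(OC)c(OC)c([N+](=O)[O-])c4)c(C)c3)nc2c1`) differs from compound 2 at one place. That change is methoxy in place of hydrogen on an aromatic carbon and amounts to a methoxy in place of hydrogen on an aromatic carbon. Among the compounds with values here, no measured pair shows this change, so no step beyond the scatter is expected in this assay in either direction. The estimated step is a 1.2-fold higher number from compound 2 to compound 3 (0.06 log units; within the scatter) and stays within the scatter. Compound 3 is expected at 14000 nM with an estimated range from 6000 nM to 32000 nM for now.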

Compound 3, half-maximal inhibitory concentration: 15400 nM
The estimate for compound 3 lay 1.1-fold (0.04 log units) below the measured number; low and high end bracket the measured number.
By their numbers in this assay, from the lowest: compounds 2, 3 and 1 (each within the scatter of the next).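

In this assay, methoxy in place of hydrogen on an aromatic carbon, ortho to a methoxy group and meta to a nitro group, gives a 1.3-fold higher number from compound 2 to compound 3 (0.10 log units; within the scatter), so this first measured pair for the change shows no difference that can be read. The second pair, with hydrogen in place of methoxy on an aromatic carbon of the core, gives a 1.1-fold lower number from compound 1 to compound 3 (0.05 log units; within the scatter) and likewise cannot be told apart. Nothing available explains these results. From the compounds shown here alone, whether an amine or a carboxylic acid at this position would give a step beyond the scatter remains open.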